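The compounds below may be only part of what the source reports. "The series", "measured", "known", "first", "only" and "open" are said of these compounds alone.

Among the compounds with values here, in a functional assay on OVCAR-8 cells (Homo sapiens) for inhibition, read by sulforhodamine B assay, with a stated time of 48 h (a higher number here means a weaker inhibitor of growth, a lower number a stronger inhibitor of growth), compound 1 (`CCCCCCCCCCCC[C@@H](O)[C@H]1CC[C@H]([C@H](O)CCCCCCCCCCNC(=O)c2ccnn2C)O1`) gives 30900 nM and stands lowest of the two numbers so far, while compound 2 (`CCCCCCCCCCCC[C@@H](O)[C@H]1CC[C@H]([C@H](O)CCCCCCCCCCC(=O)Nc2ccnn2C)O1`) gives 100000 nM as the higher one. Compound 3 (`CCCCCCCCCCCC[C@@H](O)[C@H]1CC[C@H]([C@H](O)CCCCCCCCCCOC(=O)c2ccnn2C)O1`) has not yet been measured and differs from compound 1 by this change: ((1-methyl-1H-pyrazol-5-yl)carbonyl)oxy in place of ((1-methyl-1H-pyrazol-5-yl)carbonyl)amino on a saturated chain carbon, ten or more bonds along the chain from an oxygen on a saturated carbon and a saturated ring carbon on the same chain of the shared core. Within the data shown here, the only measured step that bears on it (a 3.2-fold higher number from compound 1 to compound 2 (0.51 log units; beyond the scatter)) is modest but beyond the scatter. On that ground a small move toward a higher number is expected in this assay (a 1.4-fold higher number from compound 1 to compound 3 (0.13 log units; within the scatter)). For compound 3 the expected value is 42000 nM with an estimated range from 15000 nM to 100000 nM overall.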

Compound 3, concentration for 50% growth inhibition: 100000 nM
For compound 3 the middle estimate is 2.4-fold (0.38 log units) below the measured one, within the range that was stated.
By their numbers in this assay, from the lowest: compound 1; then compounds 2 and 3 (each within the scatter of the next).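

In this assay the ((1-methyl-1H-pyrazol-5-yl)carbonyl)oxy group in place of ((1-methyl-1H-pyrazol-5-yl)carbonyl)amino gives a 3.2-fold higher number from compound 1 to compound 3 (0.51 log units; beyond the scatter) and so shows that a second change at this position also moves toward a higher number. The two changed groups show no change at the digits printed from compound 2 to compound 3 (within the scatter) and so compound 1 alone stands apart among the three. Nothing available accounts for this result. Still open, from the compounds shown here alone, is whether a sulfonamide or an amine at this place, or a longer chain, would match or improve on compound 1.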